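Urea to amide: compound 4 judged from its neighbours

The source may report more compounds than this note shows. Statements on the series, on what has been measured and on what is new or still open speak of the compounds shown alone.

Measured compounds:
compound 1 `COc1cc(Cl)cc(-c2nn(-c3cccc(NC(=O)Nc4ccc(Cl)c(C(F)(F)F)c4)c3)cc2-c2ccncc2)c1` 990 nM
compound 2 `COc1cc(Cl)cc(-c2nn(-c3cccc(NC(=O)Nc4cc(C(F)(F)F)cc(C(F)(F)F)c4)c3)cc2-c2ccncc2)c1` 340 nM
compound 3 `COc1cc(Cl)cc(-c2nn(-c3cccc(NC(=O)Nc4ccc(Cl)c(Cl)c4)c3)cc2-c2ccncc2)c1` 1740 nM

In a functional assay on MDA-MB-468 cells (Homo sapiens) for inhibition, read by sulforhodamine B assay, with a stated time of 48 h (on this read-out lower numbers stand for stronger inhibition and higher numbers for weaker inhibition), compound 1 stands second highest of the three numbers. Compound 3 lies nearest, a 1.8-fold higher number from compound 1 to compound 3 (0.24 log units; within the scatter). Compound 2 lies furthest, with a lower number beyond the scatter. Compound 4 `COc1cc(Cl)cc(-c2nn(-c3cccc(NC(=O)c4cccc(C(F)(F)F)c4)c3)cc2-c2ccncc2)c1` differs from compound 1 by 3-(trifluoromethyl)phenyl in place of (4-chloro-3-(trifluoromethyl)phenyl)amino on a carbonyl carbon. No measured step touches this change: the one shown step swaps a halogen on the far ring, and compounds 1 and 2 differ elsewhere. With the amide hydrogen and the chlorine both gone, a weaker result is expected for compound 4, estimated at 2000 nM (range 500 nM to 8000 nM), meaning an expected step of a 2.0-fold higher number from compound 1 to compound 4 (0.31 log units; beyond the scatter).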

Compound 4, half-maximal inhibitory concentration: 4260 nM
For compound 4 the middle estimate is 2.1-fold (0.33 log units) below the measured one; the measured number falls inside the stated range.
By their numbers in this assay, from the lowest: compound 2; then compounds 1 and 3 (each within the scatter of the next); then compound 4.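

Taking out the amino nitrogen of the urea and attaching the ring straight to the carbonyl carbon gives a real loss in this assay, with a 4.3-fold higher number from compound 1 to compound 4 (0.63 log units; beyond the scatter) and a 2.4-fold higher number from compound 3 to compound 4 (0.39 log units; beyond the scatter) as the two steps. The earlier halogen swap on the far ring showed no such clear change, so this carbonyl carbon is the more sensitive place in these compounds. Nothing available here explains the loss.

Compound 4 also lacks the ring chlorine, so the two losses stay tangled. From the compounds shown here alone, how a methylene link in place of the amino nitrogen, or a carboxylic acid on the far ring, would read remains open.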